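The compounds below may be only part of what the source reports. "The series", "measured", "known", "first", "only" and "open" are said of these compounds alone.

Three compounds built on the core of compound 1 `COc1cc(N(C)C(=O)c2cccc([N+](=O)[O-])c2)cc(OC)c1OC` have been tested in a functional assay on ONS-76 cells (Homo sapiens) for cytotoxicity, read by MTT assay, with a stated time of 72 h; a higher number here means a weaker inhibitor, a lower number a stronger inhibitor. Compound 1 reaches only a limit of the assay, >= 125000 nM. Compound 2 `COc1cc(N(C)C(=O)N(C)c2ccc(F)cc2)cc(OC)c1OC` likewise returns only a limit, >= 125000 nM. Compound 3 `COc1cc(NC(=O)Nc2ccc3c(ccn3C)c2)cc(OC)c1OC` also stops at a limit, >= 125000 nM. Among the compounds with values here, compound 2 thus stands level with the other two, all at the limit of >= 125000 nM in this assay, at which 3 of the 3 values shown sit, and no step between measured compounds can be read from these numbers. Compound 4 `COc1cc(N(C)C(=O)N(C)c2cccc(F)c2)cc(OC)c1OC` differs from compound 2 by 3-fluorophenyl in place of 4-fluorophenyl on an amide-type nitrogen. Because compound 2 sits at its limit >= 125000 nM, there is no number to build on. Compound 4 is therefore expected to show a number no higher from compound 2 to compound 4 (the limit leaves the size open), no step beyond the scatter. Compound 4 is estimated at 125000 nM in this assay, within 60000 nM to 300000 nM, most likely again reported only as a limit.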

Compound 4, half-maximal inhibitory concentration: >= 125000 nM
Compound 4 ended at the assay's limit; the forecaster's own chance of this, stated with the estimate: 85%; the middle value sits exactly at the limit.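

No step can be read from compound 2 to compound 4, as both values are only limits in this assay. The compounds shown leave open how 3-fluorophenyl and 4-fluorophenyl truly compare, and what change to the shared core would give a measurable number.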